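From Dichlorobenzyl to Fluorobenzyl: Expecting Compound 4

This account rests on a few compounds, and the source may have more. Where it says the series, first, only, none or still open, it means among the compounds named here.

Compound 1, `N#Cc1ccc(Cn2cc(COc3ccc4c(=O)ccoc4c3)nn2)cc1`, gives > 100000 nM in a functional assay on SW480 cells (Homo sapiens) for cytotoxicity, read by MTT assay, with a stated time of 48 h; on this read-out higher numbers stand for weaker inhibition and lower numbers for stronger inhibition; this is a limit of the assay, not a number.
Compound 2, `O=c1ccoc2cc(OCc3cn(Cc4ccc(Cl)cc4Cl)nn3)ccc12`, gives > 100000 nM; this too is a limit, not a number.
Compound 3, `CC(C)(C)c1ccc(Cn2cc(COc3ccc4c(=O)ccoc4c3)nn2)cc1`, gives 28800 nM.

Compound 2 therefore stands only at the limit of > 100000 nM in this assay, at which 2 of the 3 values shown sit, the same limit that compound 1 reaches, and no measured number places it more exactly. Compound 4, `O=c1ccoc2cc(OCc3cn(Cc4ccccc4F)nn3)ccc12`, is not yet measured. It differs from compound 2 in one place: 2-fluorophenyl in place of 2,4-dichlorophenyl on a saturated chain carbon bound to an aromatic nitrogen.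

For the measured compounds named here, two measured steps touch this part of the shared core. The step that the two limits leave unreadable from compound 1 to compound 2 cannot be read in size, since both ends are limits. The step of an at least 3.4-fold lower number from compound 1 to compound 3 (0.54 log units; beyond the scatter) shows that a change of the group on this ring can matter, at least modestly. Neither step involves a 2-fluorophenyl, so no direct guide exists for the change to compound 4. The step of a number no higher from compound 2 to compound 4 (the limit leaves the size open) is therefore expected to stay close to none, with compound 4 most likely remaining at or near the limit. Compound 4 is estimated at 100000 nM, with a range from 30000 nM to 300000 nM.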

Compound 4, half-maximal inhibitory concentration: 11400 nM
Beside the measured number, compound 4's estimate is 8.8-fold (0.94 log units) above it, outside the stated range (below it).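

In this assay, the place on a saturated chain carbon bound to an aromatic nitrogen proves able to give a readable value with a halogen-bearing ring, and not only with the tert-butyl group of compound 3. Replacing 2,4-dichlorobenzyl with 2-fluorobenzyl gives an at least 8.7-fold lower number from compound 2 to compound 4 (0.94 log units; beyond the scatter), and replacing the 4-cyanophenyl with 2-fluorophenyl gives an at least 8.7-fold lower number from compound 1 to compound 4 (0.94 log units; beyond the scatter). Both sizes are minimums, since compound 1 and compound 2 each sit at a limit rather than a number: the limit of > 100000 nM in this assay, at which 2 of the 4 values shown sit.

This change swaps the kind of halogen and alters the substitution of the ring in one move, so the compounds shown cannot tell which of these matters. Plain benzyl, with no group on the ring, and a benzyl ring carrying an amine are not among them, so their effect here remains open.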